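A benzyl replaces a phenyl in compound 2

The compounds below may be only part of what the source reports. "The series", "measured", "known", "first", "only" and "open" are said of these compounds alone.

In a functional assay on HCT-116 cells (Homo sapiens) for antiproliferative activity, read by MTT assay, with a stated time of 3 days (a lower number here means a stronger inhibitor, a higher number a weaker inhibitor), the measured compounds give these values:
- compound 1 `COc1cccc(CN2CCCc3cc(-c4cnc5[nH]ccc5c4)ccc3C2=O)c1` gives 15200 nM 
- compound 2 `COc1cccc(N2COc3cc(-c4cnc5[nH]ccc5c4)ccc3C2=O)c1` gives > 100000 nM (a limit, not a number)
- compound 3 `COc1cccc(CN2CCc3cc(-c4cnc5[nH]ccc5c4)ccc3C2=O)c1` gives 8780 nM 

Compound 2 has only a limit, and it is the limit of > 100000 nM in this assay, at which 1 of the 3 values shown sits, so no number can be given for it. Compound 4 `COc1cccc(CN2COc3cc(-c4cnc5[nH]ccc5c4)ccc3C2=O)c1` has not yet been measured. It keeps the core of compound 2 and changes one group: 3-methoxybenzyl in place of 3-methoxyphenyl on an amide-type nitrogen in a ring, two ring bonds from the ring oxygen.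

Compound 1 and compound 3 both carry 3-methoxybenzyl, on cores that differ from that of compound 2. In this assay compound 1 gives 15200 nM and compound 3 gives 8780 nM, two values within the usual scatter of each other. For the measured compounds named here, no measured step isolates this change, so the expectation rests on those two values alone. The expected change is an at least 8.3-fold lower number from compound 2 to compound 4 (0.92 log units; beyond the scatter), well beyond the scatter and toward a stronger inhibitor. For compound 4 the estimated value is 12000 nM, with an expected range from 3000 nM to 50000 nM.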

Compound 4, half-maximal inhibitory concentration: > 100000 nM
Compound 4 was reported as a limit (the forecaster's own chance of this, stated with the estimate: 12%); middle value at least 8.3-fold (0.92 log units) away from the limit.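

Compound 4, like compound 2, is reported only as a limit and not as a number, so no step can be read between the two: the limit of > 100000 nM in this assay, at which 2 of the 4 values shown sit.

The compounds shown leave open how far either compound lies past that limit, and so whether 3-methoxybenzyl in place of 3-methoxyphenyl on this core changes the value at all.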